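This account rests on a few compounds, and the source may have more. Where it says the series, first, only, none or still open, it means among the compounds named here.

Measured so far:
compound 1 `COc1ccc(S(=O)(=O)N2CCc3cccc(NC(=O)C(C)(C)C)c32)cc1` – 289 nM
compound 2 `COC(=O)c1ccc(C(=O)Nc2cccc3c2N(S(=O)(=O)c2ccc(OC)cc2)CC3)cc1` – 312 nM
compound 3 `COc1ccc(S(=O)(=O)N2CCc3cccc(NC(=O)c4ccc(F)cc4)c32)cc1` – 45 nM

In a functional assay on MKN-45 cells (Homo sapiens) for cytotoxicity (a higher number here means a weaker inhibitor, a lower number a stronger inhibitor), compound 1 gives 289 nM, the second highest of the three numbers. Compound 2, which gives 312 nM, sits nearest: a 1.1-fold higher number from compound 1 to compound 2 (0.03 log units; within the scatter). Compound 3, which gives 45 nM, lies furthest: a 6.4-fold lower number from compound 1 to compound 3 (0.81 log units; beyond the scatter). Between compound 2 and compound 3 the gap is a 6.9-fold lower number from compound 2 to compound 3 (0.84 log units; beyond the scatter).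

Compound 4 `COc1ccc(S(=O)(=O)N2CCc3cccc(NC(=O)c4ccco4)c32)cc1` is not yet measured. It differs from compound 1 in one place: furan-2-yl in place of tert-butyl on a carbonyl carbon. The group on the carbonyl carbon thus changes from a group with no ring to one five-membered aromatic ring with one hetero atom.

Both measured steps from compound 1 bear on this, since each also replaces tert-butyl on that carbonyl carbon with a ring: a 1.1-fold higher number from compound 1 to compound 2 (0.03 log units; within the scatter) and a 6.4-fold lower number from compound 1 to compound 3 (0.81 log units; beyond the scatter). One step stayed within the scatter, the other gave a modest drop in the number; neither involved a five-membered ring, so the outcome for furan-2-yl is less certain. In this assay a step of a 1.9-fold lower number from compound 1 to compound 4 (0.28 log units; within the scatter) is therefore expected, toward a lower number, of a size between those two precedents. Compound 4 is estimated at 150 nM, with a range from 50 nM to 450 nM.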

Compound 4, half-maximal inhibitory concentration: 10.7 nM
For compound 4 the middle estimate is 14-fold (1.15 log units) above the measured one, outside the stated range (below it).
By their numbers in this assay, from the lowest: compound 4; then compound 3; then compounds 1 and 2 (each within the scatter of the next).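

In this assay, for the compounds shown here, the group on this carbonyl carbon can move the number much further than the earlier compounds showed: the change from tert-butyl gives a 27-fold lower number from compound 1 to compound 4 (1.43 log units; beyond the scatter) as a large step, whereas the earlier replacements of tert-butyl reached only a modest step. Furan-2-yl also outperforms both phenyl-bearing groups, with a 4.2-fold lower number from compound 3 to compound 4 (0.62 log units; beyond the scatter) for the replacement of 4-fluorophenyl and a 29-fold lower number from compound 2 to compound 4 (1.46 log units; beyond the scatter) for the replacement of 4-(methoxycarbonyl)phenyl, which makes compound 4 the most potent of the four compounds here; the presence of a ring alone does not set this level, as compound 2 remains within the scatter of compound 1. No measurement at hand explains why this group stands apart from the others.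

Still open, on these data alone, is whether the gain follows the ring oxygen, the five-membered aromatic ring or the attachment point, which thiophen-2-yl, tetrahydrofuran-2-yl and furan-3-yl on the same carbonyl carbon would help separate. Also open, as far as these compounds go, is how far the furan ring accepts further substitution, for instance a methyl group or a bromine on that ring.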